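The source may report more compounds than this note shows. Statements on the series, on what has been measured and on what is new or still open speak of the compounds shown alone.

Measured in a functional assay on MCF7 cells (Homo sapiens) for cytotoxicity, read by MTT assay, with a stated time of 72 h; a higher number here means a weaker inhibitor, a lower number a stronger inhibitor:
Compound 1 `CCCCCCSC(=S)N[C@H]1CCOC1=O`: > 128000 nM (a limit of the assay)
Compound 2 `O=C(CCl)Nc1ccc(C(=O)/C=C/c2ccc(Cl)cc2)cc1`: 4100 nM
Compound 3 `O=C(CSC(=S)N[C@H]1CCOC1=O)Nc1ccc(C(=O)/C=C/c2ccc(Cl)cc2)cc1`: 20300 nM

Compound 1 comes with only a limit, not a number: the limit of > 128000 nM in this assay, at which 1 of the 3 values shown sits. Of the two actual numbers, compound 3 at 20300 nM holds the higher, so it is the weaker inhibitor of the pair. Compound 2 stands at 4100 nM.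

The next compound, compound 4 `O=C(CSC(=S)N[C@H]1CCOC1=O)Nc1ccc(C(=O)/C=C/c2cccc(Cl)c2)cc1`, has the same atoms as compound 3, joined differently: 3-chlorophenyl in place of 4-chlorophenyl on a double-bonded chain carbon bound to a double-bonded chain carbon. The rest of the structure stays as it is.

Among the compounds with values here, only one measured step is available, a 5.0-fold higher number from compound 2 to compound 3 (0.69 log units; beyond the scatter). That step replaces a chlorine atom at the other end of the molecule, on a saturated chain carbon bound to a carbonyl carbon, so its size does not carry over to the present change. Within the data shown here, no measured pair shows what this swap of chlorophenyl groups does. With no evidence for a direction, no shift beyond the scatter is expected, and the estimated outcome is a 1.0-fold lower number from compound 3 to compound 4 (0.01 log units; within the scatter). For compound 4 the expected value is 20000 nM, with an estimated range from 8000 nM to 50000 nM.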

Compound 4, half-maximal inhibitory concentration: 11600 nM
Compound 4: the middle estimate sits 1.7-fold (0.24 log units) above what was measured, within the range that was stated.
By their numbers in this assay, from the lowest: compound 2; then compounds 4 and 3 (each within the scatter of the next). At a limit, above all of these: compound 1.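

In this assay, 3-chlorophenyl in place of 4-chlorophenyl, on a double-bonded chain carbon bound to a double-bonded chain carbon, gives a 1.8-fold lower number from compound 3 to compound 4 (0.24 log units; within the scatter) and so leaves the two compounds indistinguishable in this read-out. Within the data shown here, this is the first measured change at this end of the molecule, and unlike the earlier step at the other end, a 5.0-fold higher number from compound 2 to compound 3 (0.69 log units; beyond the scatter), it stays within the scatter, so among the two chlorine placements tested, the position of the chlorine on this ring makes no measurable difference here. Nothing measured in this series offers a reason for this result or says anything about how either group acts.

The compounds shown leave open whether this tolerance extends beyond chlorine, as neither a plain phenyl, nor 2-chlorophenyl, nor a methoxy-bearing or amine-bearing phenyl ring appears at this place. They also leave open how the values would respond at the other end of the molecule if an amine or a longer chain stood in place of the group that enters from compound 2 to compound 3.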